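Side chain changes and cytotoxicity in a three-compound set

A few compounds are considered here, and "the series" means these few. Any claim that something is new, unique, unknown or untested is made for them only; others in the source may bear on it.

Measured compounds:
compound 1 `Cn1nnnc1SCC(=O)Nc1ccc(-c2nc(-c3ccccc3)c(-c3ccccc3)n2C)cc1`: 49.8%
compound 2 `Cn1ccnc1SCC(=O)Nc1ccc(-c2nc(-c3ccccc3)c(-c3ccccc3)n2C)cc1`: 23.8%
compound 3 `CN1CCN(CC(=O)Nc2ccc(-c3nc(-c4ccccc4)c(-c4ccccc4)n3C)cc2)CC1`: 27.4%

In a functional assay on HT-29 cells (Homo sapiens) for cytotoxicity, read by MTT assay, with a stated time of 24 h, tested at 1.6 ug/mL (on this read-out lower numbers stand for a weaker effect and higher numbers for a stronger effect at the one concentration tested), compound 1 gives 49.8%. Compound 3 stands second highest of the three numbers; its nearest neighbour is compound 2, with a number 3.6 percentage points higher from compound 2 to compound 3 (within the scatter), so the two cannot be told apart, while compound 1 sits clearly higher, with a number 22.4 percentage points lower from compound 1 to compound 3 (beyond the scatter). The third step, a number 26 percentage points lower from compound 1 to compound 2 (beyond the scatter), likewise separates compound 1 from the rest.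

Compound 4 `CCN1CCN(CC(=O)Nc2ccc(-c3nc(-c4ccccc4)c(-c4ccccc4)n3C)cc2)CC1` is not yet measured. It differs from compound 3 only in methyl in place of hydrogen on a saturated chain carbon bound to an amine nitrogen in a ring. All three measured steps exchange the whole group on the saturated chain carbon bound to the carbonyl carbon; none of them adds a methyl to a saturated chain carbon bound to an amine nitrogen in a ring. Within the data shown here, no measured step therefore bears directly on this change, and the closest information is simply the value of compound 3 itself.

With nothing to point either way, the expected step is a number 0.4 percentage points lower from compound 3 to compound 4 (within the scatter), that is, none beyond the scatter. Compound 4 is accordingly estimated at 27% in this assay, with a range from 14% to 42%.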

Compound 4, a percentage reported as activity, at one concentration (the size of the read-out at that concentration, not a potency): 13.9%
Estimate against measurement, compound 4: 13.1 percentage points above; measured number outside the range, below it.
By their numbers in this assay, from the lowest: compounds 4, 2 and 3 (each within the scatter of the next, the first and the last beyond it); then compound 1.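

Working from this assay, this is the first change made within the 4-methylpiperazin-1-yl group rather than an exchange of the whole group, and methyl in place of hydrogen on a saturated chain carbon bound to an amine nitrogen in a ring is enough to shift the read-out, with a number 13.5 percentage points lower from compound 3 to compound 4 (beyond the scatter). The series therefore responds to a single added methyl at the far end of this side chain, not only to replacement of the whole group on the saturated chain carbon bound to a carbonyl carbon, although the 4-ethylpiperazin-1-yl group does not separate from the imidazole side chain, with a number 9.9 percentage points lower from compound 2 to compound 4 (within the scatter), and the distance to the tetrazole side chain grows, with a number 35.9 percentage points lower from compound 1 to compound 4 (beyond the scatter). Nothing available explains why this added methyl shifts the read-out.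

As far as these compounds go, it remains open whether propyl, isopropyl or 2-hydroxyethyl in place of the ethyl of 4-ethylpiperazin-1-yl would carry the read-out further in the same direction or reverse it. The read-out at a single concentration also gives no potency, so how far the step from the methyl to the ethyl group holds at other concentrations stays unresolved.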